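This account rests on a few compounds, and the source may have more. Where it says the series, first, only, none or still open, it means among the compounds named here.

Measured compounds:

compound 1 `COCn1c(CC(O)(COCc2ccccc2)COCc2ccccc2)cc(=O)[nH]c1=O` — > 100000 nM, a limit of the assay

compound 2 `C[Si](C)(C)CCOCn1c(CC(O)(COCc2ccccc2)COCc2ccccc2)cc(=O)[nH]c1=O` — > 100000 nM, a limit of the assay

compound 3 `COCn1c(CC(O)(CO)CO)cc(=O)[nH]c1=O` — > 100000 nM, a limit of the assay

All three were tested in a functional assay on HeLa cells (Homo sapiens) for antiproliferative activity, read by MTT assay, with a stated time of 72 h; a lower number here means a stronger inhibitor, a higher number a weaker inhibitor. In this assay compound 1 reaches only the limit > 100000 nM. Compound 2 likewise reaches only the limit > 100000 nM. Compound 3 too reaches only the limit > 100000 nM. The change from compound 1 to compound 2 is a group of 5 heavy atoms (4 carbon, 1 silicon; no ring) in place of a hydrogen atom, on a saturated chain carbon bound to an oxygen on a saturated carbon, and its step is a step that the two limits leave unreadable from compound 1 to compound 2; this is because of the limit of > 100000 nM in this assay, at which 3 of the 3 values shown sit. The difference between the cores of compound 1 and compound 3 is not broken down here.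

Compound 4 `C[Si](C)(C)CCOCn1c(CC(O)(CO)CO)cc(=O)[nH]c1=O` is not yet measured. It differs from compound 3 by a group of 5 heavy atoms (4 carbon, 1 silicon; no ring) in place of a hydrogen atom, on a saturated chain carbon bound to an oxygen on a saturated carbon, the same change as from compound 1 to compound 2. The step is expected to be a step that the limit leaves unreadable from compound 3 to compound 4, resting on the limit of compound 3 > 100000 nM and on the unreadable step that the two limits leave unreadable from compound 1 to compound 2. Compound 4 is therefore estimated at 150000 nM, between 50000 nM and 500000 nM.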

Compound 4, half-maximal inhibitory concentration: > 100000 nM
Compound 4 gave a limit, no number (the forecaster's own chance of this, stated with the estimate: 85%); the middle value lies beyond the limit too.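

No step can be read from compound 3 to compound 4, because the values of both compounds are limits and not numbers: the limit of > 100000 nM in this assay, at which 4 of the 4 values shown sit.

The compounds shown leave open whether the silicon-containing group of 5 heavy atoms changes the activity of either core in this assay, and how the four compounds rank against one another.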